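The source may report more compounds than this note shows. Statements on the series, on what has been measured and on what is new or still open speak of the compounds shown alone.

Measured compounds:
compound 1 `CC(=O)N1N=C(c2ccc(OCc3cn(Cc4ccc([N+](=O)[O-])cc4)nn3)cc2)CC1c1ccccc1` gives 80% in a functional assay on A549 cells (Homo sapiens) for inhibition, read by sulforhodamine B assay, tested at 100 uM; a lower number here means less inhibition of growth, a higher number more inhibition of growth at the concentration tested
compound 2 `COc1cc(C2CC(c3ccc(OCc4cn(Cc5ccc([N+](=O)[O-])cc5)nn4)cc3)=NN2C(C)=O)ccc1Oc1cn(Cc2ccc([N+](=O)[O-])cc2)nn1` gives 42%
compound 3 `COc1cc(C2CC(c3ccc(Br)cc3)=NN2C(C)=O)ccc1OCc1cn(Cc2ccc([N+](=O)[O-])cc2)nn1` gives 17%

Compound 3 stands at the bottom of the three numbers. Its nearest neighbour is compound 2, which sits higher by a margin beyond the scatter, and compound 1 sits higher still, also beyond the scatter. Within the data shown here, no two of the measured compounds differ in only one place, so no single-change step is available; the three values show only that compound 3 inhibits growth least among them.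

Compound 4 `COc1cc(C2CC(c3cccc4ccccc34)=NN2C(C)=O)ccc1OCc1cn(Cc2ccc([N+](=O)[O-])cc2)nn1` is the next compound to be measured. Relative to compound 3 the change is naphthalen-1-yl in place of 4-bromophenyl on a carbon with a double bond to nitrogen, so naphthalen-1-yl in place of 4-bromophenyl on a carbon with a double bond to nitrogen.

Among the measured compounds shown here, there is no measured pair that isolates this change, so its size can only be guessed. The step from compound 3 to compound 4 in this assay is expected to be small to moderate, and on balance upward, though a result within the scatter of compound 3 would not surprise. The estimate for compound 4 is 27%, with a range from 5% to 55%, which corresponds to an expected step of a number 10 percentage points higher from compound 3 to compound 4 (within the scatter).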

Compound 4, percent growth inhibition at one concentration: 95%
The estimate for compound 4 lay 68 percentage points below the measured number, outside the stated range (above it).
By their numbers in this assay, from the lowest: compound 3; then compound 2; then compound 1; then compound 4.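

In this assay, among these compounds, the exchange of 4-bromophenyl for naphthalen-1-yl on a carbon with a double bond to nitrogen gives a number 78 percentage points higher from compound 3 to compound 4 (beyond the scatter) and is the first single-change step available. It shows that this position is far from indifferent: with the rest of compound 3 held fixed, the group on this carbon alone can move growth inhibition by a large margin. The change removes bromine and goes from one six-membered aromatic ring of carbon only to two, so this single step cannot separate these differences, and nothing at hand explains its size.

From the compounds shown here alone, whether the second ring, its point of attachment or the loss of bromine carries the step stays open, and unsubstituted phenyl, 4-chlorophenyl and naphthalen-2-yl on this same carbon would begin to separate these possibilities. Also open, going by these compounds, is whether the step holds across a range of concentrations and in other cell lines, since the reading here comes from a single concentration on one cell line.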